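Ring substituent change at the shared core: working notes

A few compounds are considered here, and "the series" means these few. Any claim that something is new, unique, unknown or untested is made for them only; others in the source may bear on it.

Measured so far in a functional assay for antagonist activity at adenosine receptor A1 (Homo sapiens); on this read-out lower numbers stand for stronger inhibition and higher numbers for weaker inhibition:
- compound 1 `CCCn1c(=O)c2nc(C3CCCC(N)C3)[nH]c2n(CCC)c1=O`: 50 nM
- compound 2 `CCCn1c(=O)c2nc(C3CCCC(NC(C)=O)C3)[nH]c2n(CCC)c1=O`: 41 nM
- compound 3 `CCCn1c(=O)c2nc(C3CCCC3C(=O)O)[nH]c2n(CCC)c1=O`: 100 nM; 140 nM (2 entries)

Compound 1 gives the highest of the two single numbers in this assay; the nearest is compound 2, and the step of a 1.2-fold lower number from compound 1 to compound 2 (0.09 log units; within the scatter) lies within the scatter. Compound 3 does not give a single number but several entries, (the several entries of compound 3 in this assay, 100 nM; 140 nM (2 entries)), and both of them sit above the value of compound 1.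

Compound 4 `CCCn1c(=O)c2nc(C3=C(C(=O)O)CCC3)[nH]c2n(CCC)c1=O` differs from compound 1 in one place: 2-carboxycyclopent-1-en-1-yl in place of 3-aminocyclohexyl on an aromatic carbon. Among the measured compounds shown here, of the measured steps only the one from compound 1 to compound 2 bears on this position, and it changed the amine without moving the number beyond the scatter. Compound 3, which carries a carboxylic acid on a five-membered ring at the same aromatic carbon, gives the higher entries shown. Compound 4 carries a carboxylic acid on a five-membered ring as well, so in this assay a number near the entries of compound 3 is expected, that is a step of a 2.4-fold higher number from compound 1 to compound 4 (0.38 log units; beyond the scatter) towards weaker inhibition.

The estimate for compound 4 in this assay is 120 nM, with a range from 50 nM to 300 nM.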

Compound 4, inhibition constant: > 10000 nM
Compound 4 was reported as a limit; the forecaster's own chance of this, stated with the estimate: 3%; at least 83-fold (1.92 log units) between middle value and limit.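

In this assay, among the compounds shown here, 2-carboxycyclopent-1-en-1-yl in place of 3-aminocyclohexyl on the aromatic carbon gives an at least 200-fold higher number from compound 1 to compound 4 (2.30 log units; beyond the scatter), the first step at this position that goes beyond the scatter and far larger than the step at the amine nitrogen, which stayed within it. For compound 4 the value of > 10000 nM is a limit of the assay and not a number. A carboxylic acid on a five-membered ring at this aromatic carbon therefore does not by itself decide the outcome, as compound 3 carries one too and still gives measured numbers: the several entries of compound 3 in this assay, 100 nM; 140 nM (2 entries)

The compounds shown do not separate the ring double bond of 2-carboxycyclopent-1-en-1-yl from its carboxylic acid as the source of the step, and no compound pairs that unsaturated ring with a different group. Open too, going by these compounds, is how a methyl ester, a primary amide or an amine on the same five-membered ring would read in this assay.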